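The source may report more compounds than this note shows. Statements on the series, on what has been measured and on what is new or still open speak of the compounds shown alone.

Measured in a functional assay on MKN-45 cells (Homo sapiens) for cytotoxicity; a lower number here means a stronger inhibitor, a higher number a weaker inhibitor:
- compound 1 `COc1ccc(S(=O)(=O)N2CCc3cccc(NC(=O)C(C)(C)C)c32)cc1`: 289 nM
- compound 2 `COc1ccc(S(=O)(=O)N2CCc3cccc(NC(C)=O)c32)cc1`: 61 nM
- compound 3 `COc1ccc(S(=O)(=O)N2CCc3cccc(NS(=O)(=O)c4ccccc4)c32)cc1`: 562 nM

Two steps place compound 3 at the high end of this small set: a 1.9-fold higher number from compound 1 to compound 3 (0.29 log units; within the scatter) and a 9.2-fold higher number from compound 2 to compound 3 (0.96 log units; beyond the scatter). Compound 4 `COc1ccc(S(=O)(=O)N2CCc3cccc(NC(=O)c4ccc(C#N)cc4)c32)cc1` makes one change to it: (4-cyanophenyl)carbonyl in place of phenylsulfonyl on a nitrogen on an aromatic ring. A carbonyl returns to that nitrogen, as in compound 1 and compound 2. Those two carbonyl compounds differ clearly, a 4.7-fold lower number from compound 1 to compound 2 (0.68 log units; beyond the scatter), so the size of the gain remains uncertain. No aromatic carbonyl has been measured yet. A modest fall in this assay is expected, and the estimated step is a 4.7-fold lower number from compound 3 to compound 4 (0.67 log units; beyond the scatter). Compound 4 is estimated at 120 nM, with an expected range of 30 nM to 450 nM.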

Compound 4, half-maximal inhibitory concentration: 89 nM
Beside the measured number, compound 4's estimate is 1.3-fold (0.13 log units) above it; low and high end bracket the measured number.
By their numbers in this assay, from the lowest: compounds 2 and 4 (each within the scatter of the next); then compounds 1 and 3 (each within the scatter of the next).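

In this assay, (4-cyanophenyl)carbonyl in place of phenylsulfonyl on this nitrogen gives a 6.3-fold lower number from compound 3 to compound 4 (0.80 log units; beyond the scatter), so the carbonyl can carry an aromatic ring without a loss against the sulfonyl. On the carbonyl carbon, 4-cyanophenyl in place of methyl gives a 1.5-fold higher number from compound 2 to compound 4 (0.16 log units; within the scatter), while 4-cyanophenyl in place of tert-butyl gives a 3.2-fold lower number from compound 1 to compound 4 (0.51 log units; beyond the scatter), which leaves tert-butyl apart from the other two carbonyl groups. Nothing measured here explains these steps.

Open, on these data alone, is whether the nitrile matters at all: a plain phenyl on the carbonyl, or an amine or carboxylic acid in place of the nitrile, would test that.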